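A Flat Series Meets a 2-Chlorophenyl Group

The source may hold more compounds than are shown below. What is called first, only, known or untested is meant among the compounds shown, and "the series" means these compounds.

In a functional assay on the whole organism with Mus musculus as the target, in the maximal electroshock model (a lower number here means that less compound is needed, a higher number that more compound is needed for the effect), compound 1 (`C[C@@H](NCc1ccc(OCc2ccccc2)cc1)C(N)=O`) gives 17.1 mg/kg, compound 2 (`CNC(=O)[C@@H](CO)NCc1ccc(OCc2ccccc2)cc1`) gives 22.8 mg/kg and compound 3 (`C[C@@H](NCc1ccc(OCCc2ccccc2)cc1)C(N)=O`) gives 12.2 mg/kg. The values of compound 3 and the other two lie within the scatter of each other. Compound 4 (`C[C@@H](NCc1ccc(OCc2ccccc2Cl)cc1)C(N)=O`) carries 2-chlorophenyl in place of benzyl on a saturated chain carbon bound to an oxygen on an aromatic ring. The closest evidence is a 1.4-fold lower number from compound 1 to compound 3 (0.15 log units; within the scatter), at that same place, while a 1.3-fold higher number from compound 1 to compound 2 (0.12 log units; within the scatter) concerns an amine nitrogen. Both steps stay within the scatter, but neither introduces chlorine. No step beyond the scatter is therefore expected in this assay. The expected step is a 1.1-fold higher number from compound 3 to compound 4 (0.06 log units; within the scatter). Compound 4 is estimated at 14 mg/kg, with an expected range of 7 mg/kg to 28 mg/kg.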

Compound 4, dose for half-maximal effect: 50.8 mg/kg
For compound 4 the middle estimate is 3.6-fold (0.56 log units) below the measured one, outside the stated range (above it).
By their numbers in this assay, from the lowest: compounds 3, 1 and 2 (each within the scatter of the next); then compound 4.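

In this assay, among the compounds shown here, the aromatic end of the chain is the first place where a change moves the number beyond the scatter: 2-chlorophenyl in place of benzyl gives a 4.2-fold higher number from compound 3 to compound 4 (0.62 log units; beyond the scatter). Chloro in place of hydrogen on an aromatic carbon does the same, with a 3.0-fold higher number from compound 1 to compound 4 (0.47 log units; beyond the scatter), so a single added chlorine sets compound 4 apart from compounds 1, 2 and 3. On these data alone, whether a fluoro or a methoxy group on that aromatic carbon would give a similar step remains open. Nothing measured here offers a reason for the step.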